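This account rests on a few compounds, and the source may have more. Where it says the series, first, only, none or still open, it means among the compounds named here.

Compound 3 `C#CCN(CCCOc1ccc2ccc(=O)oc2c1)Cc1ccccc1` gives 38600 nM in an ADME assay on isolated protein for inhibition of Amine oxidase [flavin-containing] A (Homo sapiens), read by fluorescence and Amplex Red, with stated times of 15 min and 20 min (a lower number here means a stronger inhibitor, a higher number a weaker inhibitor), the lowest of the three numbers recorded. Compound 1 `C#CCN(CCCOc1ccc2ccc(=O)oc2c1)Cc1ccc(OC)cc1` gives 60000 nM in this assay, and the step of a 1.6-fold lower number from compound 1 to compound 3 (0.19 log units; within the scatter) lies within the scatter. Compound 2 `C#CCN(CCCOc1ccc2ccc(=O)oc2c1)Cc1ccc(C)cc1` gives 116000 nM in this assay, and the step of a 3.0-fold lower number from compound 2 to compound 3 (0.48 log units; beyond the scatter) is the only change among these three that reaches beyond the scatter. Compound 4 `C#CCN(CCCOc1ccc2ccc(=O)oc2c1)Cc1ccc(C(C)C)cc1` has not been measured in this assay. It differs from compound 3 by isopropyl in place of hydrogen on an aromatic carbon, on an aromatic carbon of a six-membered aromatic ring of carbon only, para to a large group. The step that bears most directly on this change is a 3.0-fold lower number from compound 2 to compound 3 (0.48 log units; beyond the scatter), where methyl in place of hydrogen raised the number modestly; the step of a 1.9-fold higher number from compound 1 to compound 2 (0.29 log units; within the scatter) adds that methyl sat on the weaker side of methoxy as well, though within the scatter. Among the compounds with values here, no measured pair shows isopropyl itself. Because the step of a 3.0-fold lower number from compound 2 to compound 3 (0.48 log units; beyond the scatter) points that way, compound 4 is expected to give a higher number than compound 3, by about a 3.1-fold higher number from compound 3 to compound 4 (0.49 log units; beyond the scatter). Compound 4 is therefore estimated at 120000 nM in this assay, with a plausible range from 40000 nM to 400000 nM.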

Compound 4, half-maximal inhibitory concentration: 77400 nM
Beside the measured number, compound 4's estimate is 1.6-fold (0.19 log units) above it; measured number inside the range.
By their numbers in this assay, from the lowest: compounds 3, 1, 4 and 2 (each within the scatter of the next, the first and the last beyond it).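

In this assay, putting isopropyl on this aromatic carbon, para to a large group, gives a 2.0-fold higher number from compound 3 to compound 4 (0.30 log units; within the scatter), so this branched group does not clearly separate from hydrogen, whereas methyl at the same place gave a 3.0-fold lower number from compound 2 to compound 3 (0.48 log units; beyond the scatter) in the reverse direction, a step beyond the scatter. Isopropyl also cannot be told apart from the other two groups, with a 1.5-fold lower number from compound 2 to compound 4 (0.18 log units; within the scatter) and a 1.3-fold higher number from compound 1 to compound 4 (0.11 log units; within the scatter), so the numbers do not follow the count of added carbon atoms from hydrogen through methyl to isopropyl, and the single step beyond the scatter now stands without support from the new compound. No measured information is available to explain these numbers.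

The compounds shown leave open whether a group of another kind on this carbon, such as an amine, a carboxylic acid or a halogen like chlorine, would move the number beyond the scatter in either direction. They also leave open whether a longer chain on this carbon, or isopropyl placed elsewhere on the same ring, would read as isopropyl does here.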